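Hydroxybutyl for Benzyl on Two Related Cores

This account rests on a few compounds, and the source may have more. Where it says the series, first, only, none or still open, it means among the compounds named here.

Three compounds are in hand. Compound 1 `CSc1nc(NCCCCCO)c2cccnc2n1` gives 48900 nM in a functional assay on MCF7 cells (Homo sapiens) for cytotoxicity, read by MTT assay, with a stated time of 72 h; a higher number here means a weaker inhibitor of growth, a lower number a stronger inhibitor of growth. Compound 2 `CSc1nc(NCc2ccccc2)c2ccccc2n1` gives 41500 nM in this assay, and compound 3 `CSc1nc(NCc2ccccc2)c2cccnc2n1` gives 39400 nM. All three values lie within the scatter of one another. The difference between the core of compound 2 and the core of compound 3 is not broken down here.

One change recurs twice among the compounds shown: 4-hydroxybutyl in place of phenyl on a saturated chain carbon bound to a nitrogen on an aromatic ring. Its measured step is a 1.2-fold higher number from compound 3 to compound 1 (0.09 log units; within the scatter). Compound 4 `CSc1nc(NCCCCCO)c2ccccc2n1` carries the same change on the core of compound 2: 4-hydroxybutyl in place of phenyl on a saturated chain carbon bound to a nitrogen on an aromatic ring. The two places are worded alike, so the change is treated as the same kind, and the step is expected to be flat, a 1.2-fold higher number from compound 2 to compound 4 (0.08 log units; within the scatter), resting on the step of a 1.2-fold higher number from compound 3 to compound 1 (0.09 log units; within the scatter) seen for compound 1. For compound 4 the expected value in this assay is 50000 nM, between 25000 nM and 100000 nM.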

Compound 4, concentration for 50% growth inhibition: 62000 nM
For compound 4 the middle estimate is 1.2-fold (0.09 log units) below the measured one; the measured number falls inside the stated range.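

In this assay, 4-hydroxybutyl in place of phenyl gives a 1.5-fold higher number from compound 2 to compound 4 (0.17 log units; within the scatter). Set beside the earlier step, the change carries from one core to the other with no difference that can be told apart: the same change on two cores in this assay, a 1.2-fold higher number (0.09 log units; within the scatter) from compound 3 to compound 1 and a 1.5-fold higher number (0.17 log units; within the scatter) from compound 2 to compound 4, 1.2-fold (0.08 log units) apart, within the scatter of two such steps

This shows that on these two cores the change leaves the number flat, so the earlier step was a fair guide here. It does not show that the change would stay flat on any other core, and two flat steps cannot reveal whether the core alters the effect of a change that moves the number beyond the scatter.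

Still open, from the compounds shown here alone, is whether an amine, a carboxylic acid or a longer chain in place of 4-hydroxybutyl, on a saturated chain carbon bound to a nitrogen on an aromatic ring, would move the number beyond the scatter on either core.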